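Swapping phenyl in a series at the assay limit

A few compounds are considered here, and "the series" means these few. Any claim that something is new, unique, unknown or untested is made for them only; others in the source may bear on it.

Of the compounds shown here, three sharing one core have been tested in an ADME assay on DU-145 cells (Homo sapiens) for cytotoxicity, read by MTT assay, with a stated time of 72 h; a lower number here means a stronger inhibitor, a higher number a weaker inhibitor. Among the measured compounds shown here, compound 1 `COc1ccc(OC)c(C2=C(c3cc(OC)c(OC)c(OC)c3)C(=O)CC2O[SiH2]C(C)(C)C)c1` gives 100 ug/mL, the only true number here. Compound 2 `COC(=O)c1cc(C2=C(c3cc(OC)c(OC)c(OC)c3)C(=O)CC2O[SiH2]C(C)(C)C)ccc1OC` gives > 100 ug/mL, which is a limit of the assay. Compound 3 `COc1cc(C2=C(c3ccccc3)C(O[SiH2]C(C)(C)C)CC2=O)cc(OC)c1OC` gives > 100 ug/mL, which is also a limit. Compound 3 thus rests on (the limit of > 100 ug/mL in this assay, at which 2 of the 3 values shown sit), so it offers no exact starting point.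

Compound 4 `COCOc1cc(C2=C(c3cc(OC)c(OC)c(OC)c3)C(=O)CC2O[SiH2]C(C)(C)C)ccc1OC` carries 4-methoxy-3-(methoxymethoxy)phenyl in place of phenyl on a double-bonded ring carbon, the change being (4-methoxy-3-(methoxymethoxy)phenyl in place of phenyl on a double-bonded ring carbon). Three measured steps alter this same carbon. They are a number no lower from compound 1 to compound 2 (the limit leaves the size open), a number no lower from compound 1 to compound 3 (the limit leaves the size open) and a step that the two limits leave unreadable from compound 2 to compound 3. None has a readable size, so they offer no evidence that a group at this carbon moves the result by a known amount, and they give no firm direction for compound 4.

In this assay I therefore expect no step beyond the scatter. For the measured compounds named here, the only number to anchor on comes from compound 1 at 100 ug/mL. Compound 2 and compound 3 offer no such number. The estimated step is a number no higher from compound 3 to compound 4 (the limit leaves the size open). For compound 4 the expected value is 100 ug/mL, with an estimated range from 40 ug/mL to 250 ug/mL.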

Compound 4, half-maximal inhibitory concentration: 34 ug/mL
Compound 4: middle estimate off by 2.9-fold (0.47 log units), on the high side; the whole stated range lies above it.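

This carbon does respond to the group it carries. In this assay, among the compounds shown here, 4-methoxy-3-(methoxymethoxy)phenyl in place of phenyl gives an at least 2.9-fold lower number from compound 3 to compound 4 (0.46 log units; beyond the scatter), and in place of 2,5-dimethoxyphenyl it gives a 2.9-fold lower number from compound 1 to compound 4 (0.47 log units; beyond the scatter), the first step at this position with a readable size. The closest comparison changes a single group on the aromatic ring, methoxymethoxy in place of methoxycarbonyl, and gives an at least 2.9-fold lower number from compound 2 to compound 4 (0.46 log units; beyond the scatter). The earlier steps among compound 1, compound 2 and compound 3 still cannot be read, and two of the new steps give only a minimum size, because their starting compounds rest on a limit: the limit of > 100 ug/mL in this assay, at which 2 of the 4 values shown sit.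

The compounds shown leave open whether the methoxymethoxy group itself matters or whether a different group on that aromatic carbon would serve as well, and a hydroxyl, an amine or a longer ether chain there would help to separate these possibilities. They also leave open how a carboxylic acid on that same carbon would compare with the methoxycarbonyl of compound 2.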